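A few compounds are considered here, and "the series" means these few. Any claim that something is new, unique, unknown or untested is made for them only; others in the source may bear on it.

Compound 3, `CCCNC(=S)NCCC(O)c1cc(OC)ccc1N`, gives 25.4% in an assay for inhibition of Nitric oxide synthase, inducible (Homo sapiens), read by scintillation counting, with a stated time of 30 min, tested at 1 mM; a lower number here means less inhibition, a higher number more inhibition at the concentration tested (going by the name of the read-out). Among the three compounds measured there it stands second highest: compound 1, `CCCNC(=S)NCCC(O)c1ccccc1N`, gives 31.1%, and compound 2, `CCCNC(=O)NCCC(O)c1ccccc1N`, gives 19%, and both of these lie within the scatter of compound 3.

Compound 4, `CCCNC(=O)NCCC(O)c1cc(OC)ccc1N`, differs from compound 3 in one place: a group of 6 heavy atoms (4 carbon, 1 nitrogen, 1 oxygen; no ring) in place of a group of 6 heavy atoms (4 carbon, 1 nitrogen, 1 sulfur; no ring), on an amine nitrogen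

Going by the values given here, one measured step bears on this change. The same replacement, made on compound 1, gave a number 12.1 percentage points lower from compound 1 to compound 2 (beyond the scatter), a step beyond the scatter. The methoxy present in compound 3 and compound 4 but absent in compound 1 and compound 2 gave only a number 5.7 percentage points lower from compound 1 to compound 3 (within the scatter), so there is no sign from the numbers that this group alters the size of the replacement step.

The account therefore expects a step of similar size and direction for compound 4, estimated as a number 12.4 percentage points lower from compound 3 to compound 4 (beyond the scatter) in this assay. Compound 4 is estimated to give 13% in this assay, expected to lie between 3% and 23%.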

Compound 4, a percentage reported as inhibition, at one concentration (the size of the read-out at that concentration, not a potency): 14.7%
Compound 4: middle estimate off by 1.7 percentage points, on the low side, and the stated range covers the measured number.
By their numbers in this assay, from the lowest: compounds 4, 2, 3 and 1 (each within the scatter of the next, the first and the last beyond it).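

Propylcarbamoyl entering for the sulfur-bearing group on an amine nitrogen now has a second reading in this assay, a number 10.7 percentage points lower from compound 3 to compound 4 (beyond the scatter), so the lower number holds with methoxy on the shared core as well as without it: the same change on two cores in this assay, a number 12.1 percentage points lower (beyond the scatter) from compound 1 to compound 2 and a number 10.7 percentage points lower (beyond the scatter) from compound 3 to compound 4, 1.4 percentage points apart, within the scatter of two such steps Methoxy in place of hydrogen on an aromatic carbon stays small with propylcarbamoyl present too, a number 4.3 percentage points lower from compound 2 to compound 4 (within the scatter), and it matches its earlier step: the same change on two cores in this assay, a number 5.7 percentage points lower (within the scatter) from compound 1 to compound 3 and a number 4.3 percentage points lower (within the scatter) from compound 2 to compound 4, 1.4 percentage points apart, within the scatter of two such steps Across these four compounds, the two changes therefore add up with no sign that either alters the size of the other.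

On these data alone, whether the replacement step keeps its size with a longer chain in place of the propyl chain, or with an amine or a carboxylic acid in place of methoxy, stays open. All these numbers come from a single tested concentration, so they do not give potency.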